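This account rests on a few compounds, and the source may have more. Where it says the series, first, only, none or still open, it means among the compounds named here.

Of the compounds shown here, three have been measured in an assay on membranes from brain for binding affinity to Adrenergic receptor alpha-1 (Rattus norvegicus), read by radioligand binding; on this read-out lower numbers stand for stronger inhibition and higher numbers for weaker inhibition. Compound 1 `COc1cccc2c1CCCC2C(=O)NCCN1CCN(c2ccccn2)CC1` gives 838 nM, and compound 2 `COc1cccc2c1CCCC2C(=O)NCCCN1CCN(c2ccccn2)CC1` gives 327 nM. Compound 3 `COc1cccc2c1CCCC2NCCCN1CCN(c2ccccc2)CC1`, in this assay, gives 626 nM; its number sits close to that of compound 1 and close to that of compound 2, and both of those gaps stay within the usual scatter of repeated measurements, so the three compounds cannot be told apart on these numbers. Compound 4 `COc1ccccc1N1CCN(CCCNC2CCCc3c(OC)cccc32)CC1` has not yet been measured. It differs from compound 3 in one place: methoxy in place of hydrogen on an aromatic carbon. For the measured compounds named here, no measured pair shows this change, so its size has to be guessed. The step from compound 3 to compound 4 is expected to be a 5.2-fold lower number from compound 3 to compound 4 (0.72 log units; beyond the scatter), toward a stronger binding. Compound 4 is accordingly estimated at 120 nM, within 30 nM to 400 nM.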

Compound 4, half-maximal inhibitory concentration: 881 nM
Beside the measured number, compound 4's estimate is 7.3-fold (0.87 log units) below it, and the stated range ends below it.
By their numbers in this assay, from the lowest: compounds 2, 3, 1 and 4 (each within the scatter of the next, the first and the last beyond it).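

In this assay, methoxy in place of hydrogen on an aromatic carbon, ortho to a large group, gives a 1.4-fold higher number from compound 3 to compound 4 (0.15 log units; within the scatter). This is the first pair among these compounds that differs in one place, and it shows that on this read-out the change from phenyl to 2-methoxyphenyl cannot be told apart from no change at all. Nothing at hand bears on why this step stays so small. Still open, as far as these compounds go, is whether a hydroxyl group, a chlorine atom or an ethoxy group at this same place would shift the number beyond the scatter. Also open, from the compounds shown here alone, is whether methoxy would give a similar step on a different core.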